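The source may hold more compounds than are shown below. What is called first, only, known or untested is meant among the compounds shown, and "the series" means these compounds.

In an ADME assay on microsomes from liver (Homo sapiens) for metabolic stability, read by LC-MS, using NADPH, with stated times of 5 min and 30 min, tested at 1 uM (a higher number here means faster removal of the compound, a lower number slower removal), three compounds built on a shared core have been measured so far. Compound 1 `COCCC(=O)Nc1cnc(NCc2c(F)ccc3c2CCO3)n2cnnc12` gives < 3 mL.min-1.g-1, which is a limit of the assay and not a number. Compound 2 `CN(c1ccn(C)n1)c1cnc(NCc2c(F)ccc3c2CCO3)n2cnnc12` gives a true number, 11 mL.min-1.g-1. For the measured compounds named here, compound 3 `C[C@H]1CC(=O)N(c2cnc(NCc3c(F)ccc4c3CCO4)n3cnnc23)C1` gives < 3 mL.min-1.g-1, again a limit of the assay, so its position is known only as a limit, the one it shares with compound 1.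

The next compound is compound 4 `Fc1ccc2c(c1CNc1ncc(Nc3ccccc3)c3nncn13)CCO2`, with anilino in place of 4-methyl-2-oxopyrrolidin-1-yl on an aromatic carbon. The closest guide is compound 2, whose methyl(1-methyl-1H-pyrazol-3-yl)amino group, like anilino, is an amino group carrying an aromatic ring. Going by the values given here, two measured steps bear on this: an at least 3.6-fold higher number from compound 1 to compound 2 (0.56 log units; beyond the scatter) and an at least 3.6-fold lower number from compound 2 to compound 3 (0.56 log units; beyond the scatter). Both lie beyond the scatter and both leave compound 2 with the higher number. The step that the two limits leave unreadable from compound 1 to compound 3 adds nothing on size. A rise beyond the scatter is therefore expected in this assay, with the estimated step being an at least 4.6-fold higher number from compound 3 to compound 4 (0.66 log units; beyond the scatter). The estimate for compound 4 is 14 mL.min-1.g-1, with an expected range from 5 mL.min-1.g-1 to 40 mL.min-1.g-1.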

Compound 4, intrinsic clearance in microsomes: 20 mL.min-1.g-1
Compound 4: the middle estimate sits 1.4-fold (0.15 log units) below what was measured, within the range that was stated.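

In this assay, anilino gives a second case of an amino group carrying an aromatic ring at this position, and it separates clearly from the two groups without such a ring: the result is an at least 6.6-fold higher number from compound 3 to compound 4 (0.82 log units; beyond the scatter), and likewise an at least 6.6-fold higher number from compound 1 to compound 4 (0.82 log units; beyond the scatter). Against the other amino group with an aromatic ring, the result is a 1.8-fold higher number from compound 2 to compound 4 (0.26 log units; within the scatter), so anilino and methyl(1-methyl-1H-pyrazol-3-yl)amino cannot be told apart here. Across the four compounds, the two with an aromatic ring on the amino group give true numbers and none goes against this, while the other two reach only a limit of the assay, which keeps the full size of the gap unreadable: the limit of < 3 mL.min-1.g-1 in this assay, at which 2 of the 4 values shown sit.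

The compounds shown leave open whether the aromatic ring itself is what matters, and a cyclohexylamino group, with a saturated ring on the same nitrogen, would separate the ring type from the amino link. They also leave open how a fluorine or a methoxy group on the phenyl ring would move the number, and how far compound 1 and compound 3 lie under their limit.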